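A few compounds are considered here, and "the series" means these few. Any claim that something is new, unique, unknown or untested is made for them only; others in the source may bear on it.

Of the compounds shown here, two from this series have already been measured in a physicochemical assay for solubility, read by HPLC, using the shake flask method, measured as kinetic solubility, with a stated time of 2 h, at pH 7.4; on this read-out higher numbers stand for higher solubility and lower numbers for lower solubility. Compound 1 `Cc1cc(NCc2c[nH]cn2)n2nc(C)c(-c3ccccc3)c2n1` gives 14600 nM. Compound 2 `Cc1cc(NCc2ccccn2)n2ncc(-c3ccc(C#N)cc3)c2n1` is reported only as a limit of the assay, < 5000 nM, which is the limit of < 5000 nM in this assay, at which 1 of the 2 values shown sits. Compound 3 `Cc1cc(NCc2ccccn2)n2ncc(-c3ccncc3)c2n1` has not yet been measured. It differs from compound 2 in a single place: pyridin-4-yl in place of 4-cyanophenyl on an aromatic carbon. Within the data shown here, no measured pair shows a change of this kind, so the step from compound 2 to compound 3 in this assay is expected to be an increase beyond the scatter, an at least 1.8-fold higher number from compound 2 to compound 3 (0.25 log units; that floor lies within the scatter). Compound 3 is therefore estimated to give 9000 nM, with a likely range from 3000 nM to 27000 nM.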

Compound 3, solubility: 161000 nM
Estimate against measurement, compound 3: 18-fold (1.25 log units) below; measured number outside the range, above it.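

In this assay, pyridin-4-yl in place of 4-cyanophenyl on this aromatic carbon of the five-membered ring gives an at least 32-fold higher number from compound 2 to compound 3 (1.50 log units; beyond the scatter). Among these compounds, compounds 1 and 2 differ in more than one place, so this pair is the first to isolate a change at this position, and the change proves large. Compound 2 is reported only as a limit: the limit of < 5000 nM in this assay, at which 1 of the 3 values shown sits.

As far as these compounds go, whether a carboxylic acid or a morpholine on this same carbon would give a similar step remains open. So does whether this step would hold with the other substituents of compound 1.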